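The compounds below may be only part of what the source reports. "The series", "measured", "known", "first", "only" and "open" are said of these compounds alone.

Among the measured compounds shown here, the three compounds measured so far share one core and were all tested in a functional assay on the whole organism (strain Swiss) with Mus musculus as the target, in the maximal electroshock model, with a stated time of 0.25 h, at a dose of 100 mg/kg by the intraperitoneal route; a lower number here means a weaker effect, a higher number a stronger effect of the compound at the dose given. Compound 1 `COc1cccc(N2CCN(C(=O)C(C)N3C(=O)CCC3=O)CC2)c1` gives 25% in this assay, which places it second highest of the three numbers. Its nearest neighbour is compound 3 `CCC(C(=O)N1CCN(c2cccc(F)c2)CC1)N1C(=O)CCC1=O`, which gives 0%, a number lower than that of compound 1 by more than the scatter of the method. Farthest from compound 1 is compound 2 `COCC(C(=O)N1CCN(c2cccc(C(F)(F)F)c2)CC1)N1C(=O)CCC1=O`, which gives 100%, a number higher than that of compound 1 by more than the scatter. No pair among these measured compounds differs in only one place, so no single step in this assay has been measured directly.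

Compound 4 `Cc1cccc(N2CCN(C(=O)C(C)N3C(=O)CCC3=O)CC2)c1` has not yet been measured. It differs from compound 1 in one place only: methyl in place of methoxy on an aromatic carbon. For the measured compounds named here, with no measured step of this kind to lean on, the expectation rests on the value of compound 1 alone, and the step is expected to be small, not beyond the scatter in either direction. The step from compound 1 to compound 4 is expected to be a number 5 percentage points lower from compound 1 to compound 4 (within the scatter). Compound 4 is therefore estimated to give 20% in this assay, within a range from 0% to 55%.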

Compound 4, a percentage reported as activity, at one dose (the size of the read-out at that dose, not a potency): 0%
For compound 4 the middle estimate is 20 percentage points above the measured one; low and high end bracket the measured number.
By their numbers in this assay, from the lowest: compounds 3 and 4 (each within the scatter of the next); then compound 1; then compound 2.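

Among the compounds shown here, the swap is the first step read directly in this assay, and it shows that this position, on an aromatic carbon of the six-membered ring and meta to a large group, is not indifferent to the group it carries. Going from 3-methoxyphenyl to 3-methylphenyl on an otherwise unchanged structure gives a number 25 percentage points lower from compound 1 to compound 4 (beyond the scatter), a modest step but one that lies beyond the usual scatter, and with it compound 4 gives 0%. The change takes away one heavy atom, the oxygen, and with it the single hydrogen-bond acceptor of the group, but nothing measured here gives a reason for the step, which stands as an observation only.

From the compounds shown here alone, it remains open how a hydroxyl group, an ethoxy group or a chlorine atom at this same place would read out, and so whether the oxygen of methoxy matters or only the group as a whole. Going by these compounds, it is also open whether the same swap gives a step of similar size on the structures of compound 2 and compound 3, which differ from compound 1 in more than one place.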